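The compounds below may be only part of what the source reports. "The series", "measured", "known", "first", "only" and "open" are said of these compounds alone.

Compound 2, `CCCc1ccc(/C=C/C(=O)Nc2ccc3nc(CCC)cc(N)c3c2)cc1`, carries a 4-propylphenyl group at the end of its double-bonded chain. In a functional assay on HEK293 cells for activation of melanin-concentrating hormone receptor 1 (Homo sapiens), read by inositol phosphate accumulation (on this read-out higher numbers stand for an effect only at larger amounts of compound and lower numbers for an effect already at smaller amounts), compound 2 gives 3600 nM, the highest number among the three measured compounds: compound 3, `CCCc1cc(N)c2cc(NC(=O)/C=C/c3ccc(C(C)(C)C)cc3)ccc2n1`, gives 910 nM, and compound 1, `CCCc1cc(OC)c2cc(NC(=O)/C=C/c3ccc(C(F)(F)F)cc3)ccc2n1`, which also differs in its core, gives 360 nM.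

Compound 4, `CCCc1cc(N)c2cc(NC(=O)/C=C/c3ccc(Cl)c(Cl)c3)ccc2n1`, has not been measured. It arises from compound 2 by 3,4-dichlorophenyl in place of 4-propylphenyl on a double-bonded chain carbon bound to a double-bonded chain carbon. For the measured compounds named here, the one measured step at the same position, a 4.0-fold lower number from compound 2 to compound 3 (0.60 log units; beyond the scatter), shows that exchanging the propyl for another group can make the number fall by a modest amount. Compound 1, with a trifluoromethyl on the same ring, stands lower still, though its different core prevents a clean comparison. The expectation for compound 4 is therefore a lower number, in the range of a 4.0-fold lower number from compound 2 to compound 4 (0.60 log units; beyond the scatter), than for compound 2. Compound 4 is estimated at 900 nM in this assay, with a range from 250 nM to 3000 nM.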

Compound 4, half-maximal effective concentration: 990 nM
The estimate for compound 4 lay 1.1-fold (0.04 log units) below the measured number, and the stated range covers the measured number.
By their numbers in this assay, from the lowest: compound 1; then compounds 3 and 4 (each within the scatter of the next); then compound 2.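

In this assay, replacing 4-propylphenyl with 3,4-dichlorophenyl gives a 3.6-fold lower number from compound 2 to compound 4 (0.56 log units; beyond the scatter), so a lower number at this position does not depend on the new ring substituent being made of carbon alone, as the tert-butyl group is. On the shared core, compound 3 at 910 nM and compound 4 at 990 nM lie within the scatter of each other, so this assay does not separate these two replacements. Nothing shown bears on the reason for this result.

Going by these compounds, it remains open whether a single chlorine on the ring would give a step of this size, and how a ring carrying an amine or a carboxylic acid would read. Also open, on these data alone, is whether the same exchange would behave alike on the core of compound 1.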